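Sulfonyl Aryl Exchange on a Fluorinated Quinoline-type Core

This account rests on a few compounds, and the source may have more. Where it says the series, first, only, none or still open, it means among the compounds named here.

Compound 1 `COc1ccc(S(=O)(=O)c2cnc3ccc(C)cc3c2N2CCC(C)CC2)cc1Cl`: 93%
Compound 2 `Cc1ccc2ncc(S(=O)(=O)c3cccc(C#N)c3)c(N3CCC(C)CC3)c2c1`: 52%
Compound 3 `CC1CCN(c2c(S(=O)(=O)c3cccc(C#N)c3)cnc3ccc(F)cc23)CC1`: 93%

Of the compounds shown here, three have been measured in an assay on isolated protein for displacement of a labelled ligand from metabotropic glutamate receptor 5 (Homo sapiens), with a stated time of 60 min, tested at 1 uM (a lower number here means less inhibition, a higher number more inhibition at the concentration tested (going by the name of the read-out)), and a fourth, compound 4 `COc1ccc(S(=O)(=O)c2cnc3ccc(F)cc3c2N2CCC(C)CC2)cc1Cl`, awaits its number. Compound 2 gives 52% in this assay. Replacing its sulfonyl aryl group, (3-chloro-4-methoxyphenyl in place of 3-cyanophenyl on a sulfonyl sulfur), gives compound 1 with 93%, a step of a number 41 percentage points higher from compound 2 to compound 1 (beyond the scatter). The cores of compound 2 and compound 3 differ by fluoro in place of methyl on an aromatic carbon, and compound 3 gives 93%, a step of a number 41 percentage points higher from compound 2 to compound 3 (beyond the scatter). Compound 3 stands level with compound 1 at the digits reported, and both are well beyond compound 2.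

Compound 4 carries the same change relative to compound 3 that separates compound 1 from compound 2: 3-chloro-4-methoxyphenyl in place of 3-cyanophenyl on a sulfonyl sulfur, at a place described in identical words. That earlier step was a number 41 percentage points higher from compound 2 to compound 1 (beyond the scatter). Compound 3, however, already sits near the top of the scale, so the room for a further rise is small. Compound 4 is therefore expected to give about 95% in this assay, estimated between 85% and 100%, a step of roughly a number 2 percentage points higher from compound 3 to compound 4 (within the scatter) that rests on compound 3 at 93% and on the direction of a number 41 percentage points higher from compound 2 to compound 1 (beyond the scatter).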

Compound 4, a percentage reported as inhibition, at one concentration (the size of the read-out at that concentration, not a potency): 82%
Estimate against measurement, compound 4: 13 percentage points above; measured number outside the range, below it.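

On the core carrying fluoro, 3-chloro-4-methoxyphenyl in place of 3-cyanophenyl gives a number 11 percentage points lower from compound 3 to compound 4 (beyond the scatter), and with 3-chloro-4-methoxyphenyl on the sulfonyl sulfur, fluoro in place of methyl gives a number 11 percentage points lower from compound 1 to compound 4 (beyond the scatter). The sulfonyl aryl exchange therefore does not carry from one core to the other in this assay, neither in size nor in direction: the same change on two cores in this assay, a number 41 percentage points higher (beyond the scatter) from compound 2 to compound 1 and a number 11 percentage points lower (beyond the scatter) from compound 3 to compound 4, 52 percentage points apart, beyond the scatter of two such steps. The fluoro for methyl exchange behaves the same way, though four compounds tested at one concentration do not show why the steps differ or how either would run on a further core: the same change on two cores in this assay, a number 41 percentage points higher (beyond the scatter) from compound 2 to compound 3 and a number 11 percentage points lower (beyond the scatter) from compound 1 to compound 4, 52 percentage points apart, beyond the scatter of two such steps.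

The compounds shown leave open whether either exchange would keep its size or direction with an amine or a carboxylic acid on the aromatic carbon that carries fluoro or methyl. They also leave open whether the order seen at this one concentration would hold in full concentration-response measurements.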